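Replacing the sulfonyl group on a rapidly cleared compound

The source may hold more compounds than are shown below. What is called first, only, known or untested is meant among the compounds shown, and "the series" means these compounds.

In an ADME assay (liver) for metabolic stability, with Liver microsome (Homo sapiens) as the target, read by LC-MS, using microsomes and NADPH, with a stated time of 5 min, at 37 degrees C (on this read-out higher numbers stand for fast clearance and lower numbers for slow clearance), compound 2 `CCn1c([C@@H](C)NS(=O)(=O)c2cccc(C#N)c2)nc2ccc(C(F)(F)F)cc21` reads > 100 mL.min-1.g-1, which is a limit of the assay and not a number. Its relative, compound 1 `CCn1c([C@@H](C)NS(=O)(=O)c2ccc(F)cc2)nc2ccc(C(F)(F)F)cc21`, gives 26 mL.min-1.g-1. Compound 3 `CCn1c([C@@H](C)NS(=O)(=O)c2cn(C)nc2C)nc2ccc(C(F)(F)F)cc21` differs from compound 2 by 1,3-dimethyl-1H-pyrazol-4-yl in place of 3-cyanophenyl on a sulfonyl sulfur, with 1,3-dimethyl-1H-pyrazol-4-yl in place of 3-cyanophenyl on a sulfonyl sulfur. Among the compounds with values here, the only measured step at that place, an at least 3.8-fold higher number from compound 1 to compound 2 (0.58 log units; beyond the scatter), came with the entry of 3-cyanophenyl, so losing that group is expected to lower the number. The expected change is an at least 2.8-fold lower number from compound 2 to compound 3 (0.45 log units; beyond the scatter). Compound 3 is estimated at 35 mL.min-1.g-1, with an expected range of 12 mL.min-1.g-1 to 95 mL.min-1.g-1.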

Compound 3, intrinsic clearance in microsomes: 28 mL.min-1.g-1
Compound 3: middle estimate off by 1.3-fold (0.10 log units), on the high side, and the stated range covers the measured number.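

Putting 1,3-dimethyl-1H-pyrazol-4-yl in place of 3-cyanophenyl on the sulfonyl sulfur gives an at least 3.5-fold lower number from compound 2 to compound 3 (0.55 log units; beyond the scatter). That size is only a minimum, as compound 2 stands at a limit of the assay and not at a number: the limit of > 100 mL.min-1.g-1 in this assay, at which 1 of the 3 values shown sits. The pyrazole and 4-fluorophenyl cannot be told apart at this place, the step being a 1.1-fold higher number from compound 1 to compound 3 (0.03 log units; within the scatter), so a carbon-only six-membered ring and a five-membered ring with hetero atoms can read alike.

Going by these compounds, the true clearance of compound 2 stays open. So does how a plain methyl or a morpholine on the sulfonyl sulfur would read.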